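The source may report more compounds than this note shows. Statements on the series, on what has been measured and on what is new or still open speak of the compounds shown alone.

Compound 3 `Cc1ccc(-c2nn(-c3ccc(F)cc3F)cc2CNCCN2CCN(C)CC2)cc1` is one of three compounds tested in an ADME assay on Huh-7 cells (Homo sapiens) for cytotoxicity; a lower number here means that less compound is tolerated, a higher number that more compound is tolerated. In this assay compound 3 gives only a limit, > 20000 nM. Compound 1 `Cc1ccccc1-c1nn(-c2ccc(F)cc2F)cc1CNCCN(C)C` likewise reaches only a limit, > 20000 nM. Compound 2 `Cc1ccccc1-c1nn(-c2ccc(F)cc2F)cc1CNCCN1CCCCC1` also shows only a limit, > 20000 nM. For the measured compounds named here, the one directly comparable step, a step that the two limits leave unreadable from compound 1 to compound 2, cannot be sized, and the limit of > 20000 nM in this assay, at which 3 of the 3 values shown sit, describes where all three values sit. Compound 4 `COc1ccc(-c2nn(-c3ccc(F)cc3F)cc2CNCCN2CCN(C)CC2)cc1` has not yet been tested; it differs from compound 3 by methoxy in place of methyl on an aromatic carbon. Going by the values given here, no measured step concerns this change, so the expectation for compound 4 in this assay rests on the three limits alone. Compound 4 is expected to show a step that the limit leaves unreadable from compound 3 to compound 4. Compound 4 is estimated at 30000 nM, within a range from 10000 nM to 100000 nM, most likely again reported only as a limit.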

Compound 4, half-maximal cytotoxic concentration: > 20000 nM
Compound 4 gave a limit, no number; the forecaster's own chance of this, stated with the estimate: 85%; the middle value does not contradict the limit.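

For the compounds shown here, compound 3 and compound 4 both give only a limit, so no step between them can be read: the limit of > 20000 nM in this assay, at which 4 of the 4 values shown sit. Whether methoxy in place of methyl makes any difference in this assay stays open, as does the true value of each compound shown.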